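The source may hold more compounds than are shown below. What is called first, only, known or untested is meant among the compounds shown, and "the series" means these compounds.

Measured compounds:
compound 1 `CC#CC(CC(=O)O)c1ccc(OCc2ccn3cc(-c4ccc(C5CCCCC5)cc4)nc3c2)cc1`: 559 nM
compound 2 `CC#CC(CC(=O)O)c1ccc(OCc2ccc3nc(-c4ccc(C)cc4C)cn3c2)cc1`: 316 nM
compound 3 `CC#CC(CC(=O)O)c1ccc(OCc2ccc3nc(-c4ccc(C)cc4)cn3c2)cc1`: 507 nM

In an assay on isolated protein for agonist activity at Free fatty acid receptor 1 (Homo sapiens) (on this read-out higher numbers stand for an effect only at larger amounts of compound and lower numbers for an effect already at smaller amounts), compound 1 gives 559 nM, the highest of the three numbers, yet its distance to compound 3 at 507 nM and to compound 2 at 316 nM both lie within the scatter, so the three compounds cannot be put in order on these data.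

Compound 4 `CC#CC(CC(=O)O)c1ccc(OCc2ccn3cc(-c4ccccc4F)nc3c2)cc1` has not been measured in this assay. It differs from compound 1 in one place: 2-fluorophenyl in place of 4-cyclohexylphenyl on an aromatic carbon. Among the measured compounds shown here, the only measured step, a 1.6-fold higher number from compound 2 to compound 3 (0.21 log units; within the scatter), concerns a methyl on the aryl group of a different core and lies within the scatter; it says nothing direct about the exchange of a 4-cyclohexylphenyl for a 2-fluorophenyl, and no measured pair varies the cyclohexyl or introduces a fluorine. What can be said is that every aryl change seen so far, across compounds 1, 2 and 3, has stayed within the scatter.

Compound 4 is therefore expected near 800 nM, with a range from 250 nM to 2500 nM, the step of a 1.4-fold higher number from compound 1 to compound 4 (0.16 log units; within the scatter) being an estimate that leaves room for the loss of the cyclohexyl to matter more than the small aryl changes seen so far.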

Compound 4, half-maximal effective concentration: 705 nM
For compound 4 the middle estimate is 1.1-fold (0.05 log units) above the measured one; the measured number falls inside the stated range.
By their numbers in this assay, from the lowest: compounds 2, 3, 1 and 4 (each within the scatter of the next, the first and the last beyond it).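

In this assay, replacing 4-cyclohexylphenyl with 2-fluorophenyl on an aromatic carbon of the five-membered aromatic ring with 2 nitrogen gives a 1.3-fold higher number from compound 1 to compound 4 (0.10 log units; within the scatter). This is the first exchange shown at this position on the core of compound 1, and it replaces a group of 12 heavy atoms with one of 7, losing the six-membered non-aromatic ring and bringing in a fluorine, without a step beyond the scatter. So on this core the cyclohexyl ring is not needed for a number in this range, and nothing shown here explains why the two compounds cannot be told apart.

The exchange removes the cyclohexyl and introduces the fluorine in one step, so the pair cannot show what each does alone, and a plain phenyl or a 4-fluorophenyl at this place would be needed to separate them. Both groups here hold no hydrogen-bond donors or acceptors, which leaves open whether an aryl group carrying an amine, a hydroxyl or a morpholine would stay in the same range.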